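Swapping the amide aryl group in an indolylpyrimidine series

The compounds below may be only part of what the source reports. "The series", "measured", "known", "first", "only" and "open" are said of these compounds alone.

Two members of this series have numbers in a functional assay on NCI-H1975 cells (Homo sapiens) for antiproliferative activity, read by MTT assay, with a stated time of 72 h; on this read-out higher numbers stand for weaker inhibition and lower numbers for stronger inhibition. Compound 1 `COc1cc(F)c(NC(=O)c2ncccn2)cc1Nc1nccc(-c2cn(C)c3ccccc23)n1` gives 13500 nM, and compound 2 `COc1ccc(C(=O)Nc2cc(Nc3nccc(-c4cn(C)c5ccccc45)n3)c(OC)cc2N(C)C)nc1` gives 2130 nM, the lower of the two numbers and beyond the scatter away from compound 1. Compound 3 `COc1cc(N(C)C)c(NC(=O)c2ncccn2)cc1Nc1nccc(-c2cn(C)c3ccccc23)n1` is the next compound to be measured in this assay. It differs from compound 2 by pyrimidin-2-yl in place of 5-methoxypyridin-2-yl on a carbonyl carbon, the change being pyrimidin-2-yl in place of 5-methoxypyridin-2-yl on a carbonyl carbon. Among the compounds with values here, no step between measured compounds isolates this change, so its effect is not known from the data at hand. Compound 3 is therefore expected to land within a moderate distance of compound 2, most likely on the weaker side, with the step of a 1.9-fold higher number from compound 2 to compound 3 (0.27 log units; within the scatter) expected to be small relative to the gap already seen. For compound 3 the estimate in this assay is 4000 nM, with a range from 1500 nM to 12000 nM.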

Compound 3, half-maximal inhibitory concentration: 5400 nM
Beside the measured number, compound 3's estimate is 1.4-fold (0.13 log units) below it; the range from low to high includes it.
By their numbers in this assay, from the lowest: compound 2; then compound 3; then compound 1.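

In this assay, pyrimidin-2-yl in place of 5-methoxypyridin-2-yl on a carbonyl carbon gives a 2.5-fold higher number from compound 2 to compound 3 (0.40 log units; beyond the scatter) and so shows that the aryl group on this amide has a readable effect on its own. Compound 3 also isolates a second place, where dimethylamino in place of fluoro on an aromatic carbon gives a 2.5-fold lower number from compound 1 to compound 3 (0.40 log units; beyond the scatter). This shows that the gap between compound 1 and compound 2, which differ in two places, is shared between these two changes. Nothing measured here explains either step.

From the compounds shown here alone, each step rests on a single pair, so it remains open whether 5-methoxypyridin-2-yl would give a similar step with fluoro on the aromatic carbon. The compounds also leave open how a phenyl group on the carbonyl carbon, or a morpholine in place of dimethylamino, would read.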